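The compounds below may be only part of what the source reports. "The series", "measured", "known", "first", "only" and "open" are said of these compounds alone.

Compound 1 `CCCCCCCCCCCCCCSCC(COP(=O)(O)OP(=O)(O)OC[C@H]1OC(n2ccc(N)nc2=O)[C@@H](O)[C@@H]1O)OC(=O)CCCCCCCCCCC` stands in an ADME assay for solubility (a higher number here means a more soluble compound, a lower number a less soluble compound), only on a limit. Compound 1 gives > 50000000 nM, which is a limit of the assay rather than a number. Compound 2 `CCCCCCCCCCCCCCCC(=O)OC(COP(=O)(O)OP(=O)(O)OC[C@H]1OC(n2ccc(N)nc2=O)[C@@H](O)[C@@H]1O)CSCCCCCCCCCCCCCC` gives 1500000 nM in this assay. Within the data shown here, the one measured step, an at least 33-fold lower number from compound 1 to compound 2 (1.52 log units; beyond the scatter), starts from the limit of > 50000000 nM in this assay, at which 1 of the 2 values shown sits. Compound 3 `CCCCCCCCCCCCCCCCCCSCC(COP(=O)(O)OP(=O)(O)OC[C@H]1OC(n2ccc(N)nc2=O)[C@@H](O)[C@@H]1O)OC(=O)CCCCCCCCCCC` carries a change of the same kind: butyl in place of hydrogen on a saturated chain carbon, ten or more bonds along the chain from a sulfur. Among the measured compounds shown here, only the step from compound 1 to compound 2 bears on it, and a drop of comparable size is expected in this assay, an at least 25-fold lower number from compound 1 to compound 3 (1.39 log units; beyond the scatter). Compound 3 is therefore estimated at 2000000 nM, between 400000 nM and 20000000 nM.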

Compound 3, solubility: > 54000000 nM
Compound 3: a limit, no number; the forecaster's own chance of this, stated with the estimate: 20%; at least 27-fold (1.43 log units) between middle value and limit.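

Compound 1 and compound 3 both stand at a limit in this assay, and the step between them cannot be read. The compounds shown leave open whether butyl in place of hydrogen at this place on the sulfur-bound chain changes the number at all.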